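This account rests on a few compounds, and the source may have more. Where it says the series, first, only, none or still open, it means among the compounds named here.

Compound 1 `C=CCC1C(=C)C(=O)N(c2ccccc2)N1c1ccccc1` is the reference point of this account. In a functional assay on HL-60 cells (Homo sapiens) for inhibition, read by MTT assay, with a stated time of 48 h (on this read-out higher numbers stand for weaker inhibition and lower numbers for stronger inhibition), compound 1 gives 1320 nM, the lowest of the three numbers recorded. For the measured compounds named here, compound 2 `C=C1CN(C)N(c2ccc(Cl)cc2)C1=O` gives 38100 nM in this assay, and compound 3 `C=C1CN(C)N(c2ccccc2)C1=O` gives 45700 nM; both differ from compound 1 in more than one place, so no single step joins either of them to it, and their two values can only be set beside the value of compound 1. Going by the values given here, the one step between measured compounds, a 1.2-fold higher number from compound 2 to compound 3 (0.08 log units; within the scatter), concerns hydrogen in place of chloro on an aromatic carbon and does not touch the position changed here. Compound 4 `C=C1C(=O)N(c2ccccc2)N(c2ccccc2)C1c1ccccc1` differs from compound 1 by phenyl in place of allyl on a saturated ring carbon; the rest of the core of compound 1 is unchanged. Among the compounds with values here, with no measured step bearing on this change, the expectation for compound 4 in this assay is a number close to that of compound 1, a step of a 1.1-fold higher number from compound 1 to compound 4 (0.06 log units; within the scatter) being anticipated, not beyond the scatter. Compound 4 is therefore estimated at 1500 nM, within a range from 400 nM to 6000 nM.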

Compound 4, half-maximal inhibitory concentration: 1610 nM
The estimate for compound 4 lay 1.1-fold (0.03 log units) below the measured number; measured number inside the range.
By their numbers in this assay, from the lowest: compounds 1 and 4 (each within the scatter of the next); then compounds 2 and 3 (each within the scatter of the next).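

On the saturated ring carbon next to the ring nitrogen, the step with phenyl in place of allyl is a 1.2-fold higher number from compound 1 to compound 4 (0.09 log units; within the scatter) in this assay and so gives no distinction between the two groups. For the compounds shown here, this is the first measured step at this position, since the only earlier step concerned an aromatic carbon, and it shows that an aromatic ring of 6 heavy atoms and an open group of 3 heavy atoms with a double bond read alike here. No measurement available here accounts for this result. The compounds shown leave open how an amine, a carboxylic acid or a longer alkyl chain would read on this carbon. They also leave open whether a chloro on the entering phenyl would read the same as the unsubstituted phenyl.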